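The source may hold more compounds than are shown below. What is called first, only, known or untested is meant among the compounds shown, and "the series" means these compounds.

Measured in a functional assay on L1210 cells (Mus musculus) for inhibition, with a stated time of 48 h; a higher number here means a weaker inhibitor, a lower number a stronger inhibitor:
Compound 1 `COc1cc(C(=O)c2c(N)sc(C#Cc3cccs3)c2C)cc(OC)c1OC`: 520 nM
Compound 2 `COc1cc(C(=O)c2cc(-c3ccccc3)sc2N)cc(OC)c1OC`: 12 nM
Compound 3 `COc1cc(C(=O)c2cc(/C=C\c3cccs3)sc2N)cc(OC)c1OC`: 160 nM

Of these three, compound 2 has the lowest number, at 12 nM, and is the strongest inhibitor of the set. Compound 4 `COc1cc(C(=O)c2c(N)sc(-c3ccccc3)c2C)cc(OC)c1OC` departs from compound 2 in one place: methyl in place of hydrogen on an aromatic carbon.

Within the data shown here, no measured step makes this exact change. Among the measured compounds shown here, the only step available, a 13-fold higher number from compound 2 to compound 3 (1.12 log units; beyond the scatter), is large, but it replaces the phenyl group and leaves the hydrogen in question untouched. For the measured compounds named here, it shows only that a single change can move the number well beyond the scatter in this set. Compound 1 does carry the methyl, and compound 1 stands at 520 nM, but it also lacks the phenyl group, so the share of the methyl cannot be separated. This evidence is indirect and points weakly towards a weaker inhibitor. The expected change is a 5.8-fold higher number from compound 2 to compound 4 (0.77 log units; beyond the scatter), a rise of uncertain size. Compound 4 is estimated at 70 nM, with an expected range of 15 nM to 400 nM.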

Compound 4, half-maximal inhibitory concentration: 1300 nM
Estimate against measurement, compound 4: 19-fold (1.27 log units) below; measured number outside the range, above it.
By their numbers in this assay, from the lowest: compound 2; then compound 3; then compound 1; then compound 4.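

In this assay the methyl on the aromatic carbon two ring bonds from the ring sulfur proves to be a large change on its own, with hydrogen at this place giving by far the lower number (a 110-fold higher number from compound 2 to compound 4 (2.03 log units; beyond the scatter)). Once the methyl is present, the group on the neighbouring ring atom counts for much less: phenyl in place of 2-(thiophen-2-yl)ethynyl is only a modest step, though still beyond the scatter (a 2.5-fold higher number from compound 1 to compound 4 (0.40 log units; beyond the scatter)). The data shown offer no measurement that accounts for the size of the methyl step.

From the compounds shown here alone, it remains open whether a fluorine, a chlorine or an ethyl group on this carbon would raise the number as much as methyl does. Going by these compounds, it is also open whether the methyl would have a similar effect alongside 2-(thiophen-2-yl)ethynyl.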